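Amino in Place of Chloro on the Shared Core

A few compounds are considered here, and "the series" means these few. Any claim that something is new, unique, unknown or untested is made for them only; others in the source may bear on it.

Measured compounds:
compound 1, `ClCc1ccccc1Cn1cnc2c(Cl)nc(Cl)nc21`, 2040 nM
compound 2, `ClCc1cccc(Cn2cnc3nc(Cl)nc(Cl)c32)c1`, 2750 nM

In a functional assay on SN12C cells (Homo sapiens) for cytotoxicity, read by sulforhodamine B assay, with a stated time of 48 h (on this read-out lower numbers stand for stronger inhibition of growth and higher numbers for weaker inhibition of growth), compound 1 gives 2040 nM, the lowest of the two numbers shown. Compound 2 gives 2750 nM in this assay, and its value sits within the scatter of that of compound 1, so the two compounds show no separation on this read-out.

Compound 3, `Nc1nc(Cl)c2ncn(Cc3ccccc3CCl)c2n1`, has not yet been measured in this assay. It differs from compound 1 in one place: amino in place of chloro on an aromatic carbon. Going by the values given here, no pair of measured compounds shows this exchange, so nothing here tells how the amino group will be read against the chloro group it replaces. The two measured compounds, differing only in where the chloromethyl-bearing benzyl group sits, give numbers close together, which suggests this series does not swing widely with small changes. The expectation is therefore a step of modest size, if any beyond the scatter, leaning towards a somewhat higher number. Compound 3 is estimated at 3000 nM, with a range from 1000 nM to 9000 nM. This amounts to an expected 1.5-fold higher number from compound 1 to compound 3 (0.17 log units; within the scatter).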

Compound 3, concentration for total growth inhibition: 5620 nM
Compound 3: the middle estimate sits 1.9-fold (0.27 log units) below what was measured, within the range that was stated.
By their numbers in this assay, from the lowest: compounds 1 and 2 (each within the scatter of the next); then compound 3.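

In this assay, amino in place of chloro on the aromatic carbon between two ring nitrogen atoms gives a 2.8-fold higher number from compound 1 to compound 3 (0.44 log units; beyond the scatter). Going by these compounds alone, this is the first step between compounds differing in one place here, and it shows that this position responds to a change of group: the step is modest, yet it lies beyond the scatter, and its direction is towards weaker inhibition of growth. The chloro that leaves carries 0 hydrogen-bond donors and 0 hydrogen-bond acceptors, the amino that enters carries 1 hydrogen-bond donor and 1 hydrogen-bond acceptor, but no measurement at hand accounts for the step or links it to that difference.

With a single exchange at this position, the compounds shown leave open whether the higher number follows from the arrival of amino or the departure of chloro, a question that a methylamino group, a methoxy group or a plain hydrogen on the same carbon could help to separate. They also leave open whether the same exchange would give a step of similar size and direction on compound 2.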